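Benzamido replacing a thiazolyl carbamoyl on the saturated ring

The source may hold more compounds than are shown below. What is called first, only, known or untested is meant among the compounds shown, and "the series" means these compounds.

Three compounds sharing one fused core have been tested in a functional assay on HEK293 cells for agonist activity at G-protein coupled receptor 39 (Homo sapiens), read by scintillation proximity assay and inositol phosphate accumulation, with a stated time of 75 min; on this read-out higher numbers stand for an effect only at larger amounts of compound and lower numbers for an effect already at smaller amounts:

- compound 1 `Cc1nn(-c2ncnc3nc[nH]c23)c2c1C(OCC(=O)c1ccc(F)cc1)CC(=O)N2` gives 973 nM
- compound 2 `Cc1cc(C)nc(-n2nc(C)c3c2NC(=O)CC3c2ccc(F)cc2F)n1` gives > 10000 nM, which is a limit of the assay and not a number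
- compound 3 `Cc1nn(-c2ncnc3nc[nH]c23)c2c1C(C(=O)N(C)c1nccs1)CC(=O)N2` gives 3300 nM

Among the two numbers, compound 3 stands with the higher one; its gap to compound 1 lies beyond the usual scatter of repeated measurements. Compound 2 carries a different group on the ring nitrogen of the core and reaches only the limit of the assay.

Compound 4 `Cc1nn(-c2ncnc3nc[nH]c23)c2c1C(NC(=O)c1ccccc1)CC(=O)N2` has not yet been measured. It keeps the core and the ring-nitrogen substituent of compound 3 and changes only the group on the saturated ring carbon: benzamido in place of methyl(1,3-thiazol-2-yl)carbamoyl on a saturated ring carbon. The leaving and entering groups are of the same size in heavy atoms, but an amide attached through its nitrogen, with a hydrogen-bond donor and a plain phenyl ring, takes the place of an amide attached through its carbonyl carbon bearing a thiazole.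

Among the compounds with values here, no measured pair shows this change, so the expected step is uncertain. In this assay the step of a 1.3-fold lower number from compound 3 to compound 4 (0.12 log units; within the scatter) is estimated as small, not clearly beyond the scatter in either direction. Compound 4 is expected to give about 2500 nM, within a range from 600 nM to 10000 nM.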

Compound 4, half-maximal effective concentration: 158 nM
For compound 4 the middle estimate is 16-fold (1.20 log units) above the measured one; measured number below the stated range.
By their numbers in this assay, from the lowest: compound 4; then compound 1; then compound 3. At a limit, above all of these: compound 2.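

In this assay the saturated ring carbon of the shared core responds strongly to the group it carries: benzamido in place of methyl(1,3-thiazol-2-yl)carbamoyl brings a 21-fold lower number from compound 3 to compound 4 (1.32 log units; beyond the scatter) with only this one place changed. Within the data shown here, both groups hold the same number of heavy atoms, so their size counted this way does not decide the result at this position, a point that the earlier compounds, with no pair differing in one place, could not show. The change alters three things together, since the amide is now attached through its nitrogen, the amide hydrogen appears and a phenyl ring takes the place of the thiazole, and nothing measured here explains the size of the step.

Which of these three features carries the step stays open, and a benzamido with a methyl group on its nitrogen, or a thiazole-carbonylamino group attached through its nitrogen like benzamido, would begin to separate them. As far as these compounds go, how far the effect extends is also open, for example with a chloro or methoxy group on the phenyl ring or with a longer chain between that ring and the amide.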